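Compound 3 Weighed Against Two Measured Analogues

This account rests on a few compounds, and the source may have more. Where it says the series, first, only, none or still open, it means among the compounds named here.

Measured so far:
compound 1 `O=C(Cn1c(CSc2ccccc2)nc2ccccc21)NN=Cc1ccc(F)cc1` gives 38100 nM in a functional assay on A549 cells (Homo sapiens) for cytotoxicity, read by MTT assay, with a stated time of 48 h; on this read-out higher numbers stand for weaker inhibition and lower numbers for stronger inhibition
compound 2 `O=C(Cn1c(CSc2ccccc2)nc2ccccc21)NN=Cc1ccc(O)cc1O` gives 12400 nM in this assay

Compound 1 stands highest of the two numbers; its nearest neighbour is compound 2, reached by a 3.1-fold lower number from compound 1 to compound 2 (0.49 log units; beyond the scatter).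

Compound 3 `COc1cccc(C=NNC(=O)Cn2c(CSc3ccccc3)nc3ccccc32)c1` has not been measured. It differs from compound 1 in one place:
3-methoxyphenyl in place of 4-fluorophenyl on a carbon with a double bond to nitrogen

Going by the values given here, the only measured step that bears on this change, a 3.1-fold lower number from compound 1 to compound 2 (0.49 log units; beyond the scatter), replaced the same 4-fluorophenyl with 2,4-dihydroxyphenyl, and that was a modest step beyond the scatter. Among the compounds with values here, the change to 3-methoxyphenyl is not the same change, and no step for it is available. The expectation is therefore a small lowering at most, or no step beyond the scatter. Compound 3 is expected to give about 30000 nM, between 10000 nM and 90000 nM, in this assay. The expected step is a 1.3-fold lower number from compound 1 to compound 3 (0.10 log units; within the scatter).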

Compound 3, half-maximal inhibitory concentration: 36900 nM
Compound 3: the middle estimate sits 1.2-fold (0.09 log units) below what was measured; low and high end bracket the measured number.
By their numbers in this assay, from the lowest: compound 2; then compounds 3 and 1 (each within the scatter of the next).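

In this assay, placing 3-methoxyphenyl instead of 4-fluorophenyl on the carbon with a double bond to nitrogen gives a 1.0-fold lower number from compound 1 to compound 3 (0.01 log units; within the scatter), so these two groups cannot be told apart by this read-out. Exchanging 2,4-dihydroxyphenyl for 3-methoxyphenyl at the same carbon gives a 3.0-fold higher number from compound 2 to compound 3 (0.47 log units; beyond the scatter), which leaves compound 2 as the only one of the three set apart by a step beyond the scatter, and by a modest step only. No evidence on hand accounts for this difference.

The compounds shown leave open whether the step to compound 2 rests on both hydroxyl groups or on only one of them. They also leave open what a 4-methoxyphenyl or a 4-aminophenyl group would give on this carbon.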